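Oral rat exposure of imidazopyrazine anilides: estimate for compound 4

The source may report more compounds than this note shows. Statements on the series, on what has been measured and on what is new or still open speak of the compounds shown alone.

Measured so far:
- compound 1 `Cc1cn2c(-c3cn[nH]c3)cnc2c(Nc2cc(Cn3cccn3)ns2)n1`: "not determined" (no result reported)
- compound 2 `Cc1cn2c(-c3cn[nH]c3)cnc2c(Nc2cc(Cc3ccncc3)ns2)n1`: "not determined" (no result reported)
- compound 3 `Cc1ccc(Cc2cc(Nc3nc(C)cn4c(-c5cn[nH]c5)cnc34)sn2)nc1`: 1370 ng.h/mL

Compound 1 stands without a number in an ADME assay on the whole organism for pharmacokinetics, with Rattus norvegicus as the target, with a stated time of 6 h, at a dose of 10 mg/kg by the oral route; on this read-out lower numbers stand for lower exposure and higher numbers for higher exposure at the dose given: its entry reads "not determined" (no result reported), and compound 2 likewise reads "not determined" (no result reported). The one figure in this assay comes from compound 3, which gives 1370 ng.h/mL. Among the measured compounds shown here, no step between two measured compounds is available, so nothing can be said about what a change on the saturated chain carbon does to exposure from the numbers themselves.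

Compound 4 `Cc1cn2c(-c3cn[nH]c3)cnc2c(Nc2cc(Cc3cccc(F)n3)ns2)n1` differs from compound 1 by 6-fluoropyridin-2-yl in place of 1H-pyrazol-1-yl on a saturated chain carbon bound to an aromatic carbon. For the measured compounds named here, since compound 1 carries no number, no step from compound 1 to compound 4 can be sized or given a direction in this assay; the expectation for compound 4 rests on compound 3 alone. Because compound 3 gives 1370 ng.h/mL, compound 4 is expected to give about 1000 ng.h/mL, with a plausible range from 300 ng.h/mL to 3500 ng.h/mL.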

Compound 4, area under the concentration-time curve: 2970 ng.h/mL
For compound 4 the middle estimate is 3.0-fold (0.47 log units) below the measured one, and the stated range covers the measured number.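

In this assay, the saturated chain carbon bound to an aromatic carbon now has its first readable step: 6-fluoropyridin-2-yl in place of 5-methylpyridin-2-yl gives a 2.2-fold higher number from compound 3 to compound 4 (0.34 log units; beyond the scatter), so the read-out responds to a change in the group held at this place. Steps involving compound 1 or compound 2 cannot be read, so the 1H-pyrazol-1-yl and pyridin-4-yl groups remain unplaced relative to the two fluoro and methyl pyridines. No measurement at hand accounts for the step.

Still open, on these data alone, is where an unsubstituted pyridin-2-yl would fall relative to the methyl and fluoro groups, which would separate the contribution of each. Also open, as far as these compounds go, is how a saturated amine such as morpholin-4-yl would read at the same carbon.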